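A few compounds are considered here, and "the series" means these few. Any claim that something is new, unique, unknown or untested is made for them only; others in the source may bear on it.

Compound 3 `COc1ccc(-c2c(S(=O)(=O)c3ccc(OC)cc3)cnc3cc(F)ccc23)cc1` carries a 4-methoxyphenyl on its sulfonyl sulfur, and in an ADME assay on microsomes from liver (Homo sapiens) for metabolic stability, tested at 2.5 uM (on this read-out lower numbers stand for slow clearance and higher numbers for fast clearance), compound 3 gives 1.18 mL/min. Among the three measured compounds this sits at the low end together with compound 2 `COc1ccc(S(=O)(=O)c2cnc3cc(F)ccc3c2-c2ccc(Cl)cc2)cc1`, which gives 1.28 mL/min in this assay; the change a 1.1-fold lower number from compound 2 to compound 3 (0.04 log units; within the scatter) shows how little separates them. Compound 1 `COc1ccc(-c2c(S(=O)(=O)c3cc(F)cc(F)c3)cnc3c(F)cccc23)cc1` gives 2.59 mL/min in this assay, a higher number that lies beyond the scatter. Compound 4 `COc1ccc(-c2c(S(=O)(=O)c3ccc(C)c(C)c3)cnc3cc(F)ccc23)cc1` is the next step: 3,4-dimethylphenyl in place of 4-methoxyphenyl on a sulfonyl sulfur. For the measured compounds named here, the only measured step that touches this sulfonyl substituent is the one from compound 2 to compound 3, which stayed within the scatter, so nothing here points to a shift beyond the scatter. For compound 4 the expected step is a 1.3-fold higher number from compound 3 to compound 4 (0.10 log units; within the scatter), and the estimate in this assay is 1.5 mL/min, most likely between 0.8 mL/min and 2.8 mL/min.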

Compound 4, intrinsic clearance in a liver preparation (reported as CLH), per the amount of preparation that the assay uses: 4.13 mL/min
Beside the measured number, compound 4's estimate is 2.8-fold (0.44 log units) below it; measured number outside the range, above it.
By their numbers in this assay, from the lowest: compounds 3 and 2 (each within the scatter of the next); then compounds 1 and 4 (each within the scatter of the next).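

In this assay, a 3.5-fold higher number from compound 3 to compound 4 (0.54 log units; beyond the scatter) is the first listed step between two compounds that goes beyond the scatter, so the group on the sulfonyl sulfur can change clearance measurably. The two groups have the same number of heavy atoms, but 3,4-dimethylphenyl has no oxygen and no hydrogen-bond acceptor. Nothing available explains why the number rises.

The compounds shown leave open whether one methyl group would give a similar rise, or how an amine or a carboxylic acid on that phenyl ring would behave.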